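Five-membered heteroaryl on sulfur: expected recovery for compound 4

The source may report more compounds than this note shows. Statements on the series, on what has been measured and on what is new or still open speak of the compounds shown alone.

Three measured compounds share one core and differ in the group on the sulfur and in a methyl on an aromatic carbon. In a functional assay on MCF7 cells (Homo sapiens) for cytotoxicity, read by MTT assay, with a stated time of 24 h, tested at 32 ug/mL (a lower number here means a weaker effect, a higher number a stronger effect of the compound at the concentration tested), compound 1 `Cn1c(-c2ccc(NC(=O)CSc3nc4ccccc4o3)cc2)nc(-c2ccccc2)c1-c1ccccc1` gives 71.5%. Compound 2 `Cc1ccc2oc(SCC(=O)Nc3ccc(-c4nc(-c5ccccc5)c(-c5ccccc5)n4C)cc3)nc2c1` gives 57.7%, and compound 3 `Cn1nnnc1SCC(=O)Nc1ccc(-c2nc(-c3ccccc3)c(-c3ccccc3)n2C)cc1` gives 77.5%. Compound 2 stands lowest of the three numbers, with compound 1 nearest and compound 3 furthest. The steps read: a number 13.8 percentage points lower from compound 1 to compound 2 (beyond the scatter); a number 6 percentage points higher from compound 1 to compound 3 (within the scatter); a number 19.8 percentage points higher from compound 2 to compound 3 (beyond the scatter).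

Compound 4 `Cc1nnc(SCC(=O)Nc2ccc(-c3nc(-c4ccccc4)c(-c4ccccc4)n3C)cc2)s1` differs from compound 2 in one place: 5-methyl-1,3,4-thiadiazol-2-yl in place of 5-methyl-1,3-benzoxazol-2-yl on a sulfur. The step that bears most directly is a number 19.8 percentage points higher from compound 2 to compound 3 (beyond the scatter), where the same group left the sulfur and a five-membered aromatic ring with hetero atoms entered. The step of a number 6 percentage points higher from compound 1 to compound 3 (within the scatter) adds that benzoxazolyl and methyltetrazolyl on the sulfur sit within scatter of each other. Among the compounds with values here, an upward step from compound 2 is therefore expected, somewhat short of the full gain seen in a number 19.8 percentage points higher from compound 2 to compound 3 (beyond the scatter), since only one comparable exchange is known. Compound 4 is expected to give about 72%, with a range from 58% to 84%. The expected step is a number 14.3 percentage points higher from compound 2 to compound 4 (beyond the scatter).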

Compound 4, a percentage reported as activity, at one concentration (the size of the read-out at that concentration, not a potency): 83.4%
Beside the measured number, compound 4's estimate is 11.4 percentage points below it; measured number inside the range.
By their numbers in this assay, from the lowest: compound 2; then compounds 1, 3 and 4 (each within the scatter of the next, the first and the last beyond it).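

In this assay, a second single five-membered aromatic ring on the sulfur also gives a clear gain over 5-methyl-1,3-benzoxazol-2-yl, a number 25.7 percentage points higher from compound 2 to compound 4 (beyond the scatter), so the recovery is not confined to 1-methyl-1H-tetrazol-5-yl. Within the data shown here, the two five-membered rings are not separated, a number 5.9 percentage points higher from compound 3 to compound 4 (within the scatter), but 5-methyl-1,3,4-thiadiazol-2-yl is the first of them to stand clear of the unmethylated 1,3-benzoxazol-2-yl, a number 11.9 percentage points higher from compound 1 to compound 4 (beyond the scatter), although compound 3 does not, so any preference for the single ring over the fused ring has compound 3 against it. No measurement here bears on why the group on the sulfur shifts this read-out.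

Still open, going by these compounds, is what the methyl on the 1,3,4-thiadiazole ring contributes. Also open, on these data alone, is whether the aromatic ring on the sulfur is needed at all, as an amine or a carboxylic acid on a longer chain in its place would show.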